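Swapping chloro for methoxy on the indole core: expected toxicity shift

The source may hold more compounds than are shown below. What is called first, only, known or untested is meant among the compounds shown, and "the series" means these compounds.

Compound 1 `O=C(CSc1c[nH]c2cc(Cl)ccc12)Nc1ccc(Cl)c(Cl)c1` gives 67800 nM in an ADME assay on HEK-293T cells (Homo sapiens) for cytotoxicity, read by CCK-8 assay, with a stated time of 48 h; on this read-out higher numbers stand for lower toxicity in this test and lower numbers for higher toxicity in this test. Compound 2 `O=C(CSc1c[nH]c2c(Cl)cccc12)Nc1ccc(Cl)c(Cl)c1` gives 49100 nM in this assay. Compound 3 `COc1cccc2c(SCC(=O)Nc3ccc(Cl)c(Cl)c3)c[nH]c12` reaches only the limit of the test, > 100000 nM in this assay, and no number beyond that is known.

All three share the same amide-linked, sulfur-bridged scaffold and differ only in what sits on the six-membered ring of the fused core. Compound 1 and compound 2 carry the same atoms joined differently; how their two cores differ is not broken down here. Compound 1 gives 67800 nM and compound 2 gives 49100 nM, values that lie within the scatter of each other, so no order between them is claimed.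

From compound 2 to compound 3 the change is methoxy in place of chloro on an aromatic carbon. It gave an at least 2.0-fold higher number from compound 2 to compound 3 (0.30 log units; that floor lies within the scatter). Only a floor can be stated for that step, since compound 3 sits at the limit of > 100000 nM in this assay, at which 1 of the 3 values shown sits.

Compound 4 `COc1ccc2c(SCC(=O)Nc3ccc(Cl)c(Cl)c3)c[nH]c2c1` is not yet measured. From compound 1 to compound 4 the change is methoxy in place of chloro on an aromatic carbon. It is the same kind of change as from compound 2 to compound 3, though not the same: the earlier one is placed ortho to a fused ring and meta to a fused ring, whereas this one is placed meta to a fused ring and para to a fused ring.

Resting on compound 2 to compound 3 giving an at least 2.0-fold higher number from compound 2 to compound 3 (0.30 log units; that floor lies within the scatter), compound 4 is expected to show a step of a 1.8-fold higher number from compound 1 to compound 4 (0.25 log units; within the scatter). Compound 4 is estimated at 120000 nM, in a range from 50000 nM to 260000 nM, and the test may well report only its limit.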

Compound 4, half-maximal cytotoxic concentration: 78400 nM
For compound 4 the middle estimate is 1.5-fold (0.18 log units) above the measured one; the measured number falls inside the stated range.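

Methoxy in place of chloro, here meta to a fused ring and para to a fused ring, gave a 1.2-fold higher number from compound 1 to compound 4 (0.06 log units; within the scatter) in this assay, so on this core the swap produced no shift that stands out from the usual variation between repeated measurements. Set beside the same kind of change on the other core, this step shows only that the two results are compatible, and it does not establish that the change carries over with the same size: the same change on two cores in this assay, an at least 2.0-fold higher number (0.30 log units; that floor lies within the scatter) from compound 2 to compound 3 and a 1.2-fold higher number (0.06 log units; within the scatter) from compound 1 to compound 4; the limit leaves it open whether they differ. The step to compound 3 could be much larger than its floor or close to it, and the comparison stays unresolved because compound 3 gives only a limit, not a number: the limit of > 100000 nM in this assay, at which 1 of the 4 values shown sits.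

The compounds shown leave open whether any group other than chloro or methoxy on this six-membered ring, such as an amine or a carboxylic acid, would move the number beyond the scatter. As far as these compounds go, the amide-linked, sulfur-bridged part is the same in all four compounds, so what a longer chain there would do in this assay also remains open.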